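Swapping the urea aryl group: dichlorophenyl to trifluoromethylphenyl

This account rests on a few compounds, and the source may have more. Where it says the series, first, only, none or still open, it means among the compounds named here.

Of the compounds shown here, two sharing one core have been tested in a functional assay on OVCAR-5 cells (Homo sapiens) for inhibition, read by sulforhodamine B assay, with a stated time of 48 h, tested at 1 uM; a lower number here means a stronger effect, a higher number a weaker effect of the compound at the concentration tested. Compound 1 `COc1cc(Cl)cc(-c2nn(-c3cccc(NC(=O)Nc4cc(C(F)(F)F)cc(C(F)(F)F)c4)c3)cc2-c2ccncc2)c1` gives 59%. Compound 2 `COc1cc(Cl)cc(-c2nn(-c3cccc(NC(=O)Nc4ccc(Cl)c(Cl)c4)c3)cc2-c2ccncc2)c1` gives 87%, the higher of the two numbers and therefore the weaker effect, with compound 1 lying beyond the scatter below it. Compound 3 `COc1cc(Cl)cc(-c2nn(-c3cccc(NC(=O)Nc4cccc(C(F)(F)F)c4)c3)cc2-c2ccncc2)c1` has not yet been measured. It differs from compound 2 by one change: 3-(trifluoromethyl)phenyl in place of 3,4-dichlorophenyl on an amide-type nitrogen. For the measured compounds named here, compound 1 also carries trifluoromethyl groups at this position and shows the stronger effect, so a move toward lower numbers is possible, but no measured pair isolates this exact change, and a result within the scatter of compound 2 cannot be excluded. The step from compound 2 to compound 3 is expected to be a number 12 percentage points lower from compound 2 to compound 3 (beyond the scatter). Compound 3 is estimated at 75%, within a range from 55% to 95%.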

Compound 3, a percentage reported as activity, at one concentration (the size of the read-out at that concentration, not a potency): 88%
Beside the measured number, compound 3's estimate is 13 percentage points below it, within the range that was stated.
By their numbers in this assay, from the lowest: compound 1; then compounds 2 and 3 (each within the scatter of the next).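

Swapping 3,4-dichlorophenyl for 3-(trifluoromethyl)phenyl on the amide-type nitrogen gives a number 1 percentage points higher from compound 2 to compound 3 (within the scatter) in this assay so at this place the two groups cannot be told apart. One trifluoromethyl group alone therefore does not bring the stronger effect of compound 1: putting hydrogen in place of one of its two trifluoromethyl groups gives a number 29 percentage points higher from compound 1 to compound 3 (beyond the scatter) and a higher number here means a weaker effect. Nothing measured here explains why the second trifluoromethyl group makes this difference.

On these data alone, it stays open whether the second trifluoromethyl group is needed as such, or whether another second group on that ring would serve as well. A ring carrying a nitrile or a methoxy group in that place would speak to this, as would a plain phenyl ring.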